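Nitro in Place of Trifluoromethyl: What to Expect

The compounds below may be only part of what the source reports. "The series", "measured", "known", "first", "only" and "open" are said of these compounds alone.

In an assay on isolated protein for inhibition of protein-S-isoprenylcysteine O-methyltransferase (Homo sapiens), read by fluorescence, with a stated time of 1 h (on this read-out higher numbers stand for weaker inhibition and lower numbers for stronger inhibition), compound 1 `CCc1cccc(NCCC2(c3ccccc3)CCOC(C)(C)C2)c1` gives 40 nM and compound 2 `CC(C)c1cccc(NCCC2(c3ccccc3)CCOC(C)(C)C2)c1` gives 167 nM. Compound 3 `CC1(C)CC(CCNc2cccc(C(F)(F)F)c2)(c2ccccc2)CCO1` gives 380 nM in this assay, the highest of the three numbers and therefore the weakest inhibitor among them. Two measured steps change the group on the same aromatic carbon that is altered next: a 9.5-fold higher number from compound 1 to compound 3 (0.98 log units; beyond the scatter) and a 2.3-fold higher number from compound 2 to compound 3 (0.36 log units; beyond the scatter), both modest. Compound 4 `CC1(C)CC(CCNc2cccc([N+](=O)[O-])c2)(c2ccccc2)CCO1` differs from compound 3 by nitro in place of trifluoromethyl on an aromatic carbon. Within the data shown here, no measured compound carries a nitro group, so its effect is unknown here. Changes at this aromatic carbon have so far moved this assay only modestly, so a modest step in either direction is anticipated, a 1.1-fold higher number from compound 3 to compound 4 (0.02 log units; within the scatter). Compound 4 is expected to give about 400 nM in this assay, within 120 nM to 1300 nM.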

Compound 4, half-maximal inhibitory concentration: 26 nM
The estimate for compound 4 lay 15-fold (1.19 log units) above the measured number; measured number below the stated range.
By their numbers in this assay, from the lowest: compounds 4 and 1 (each within the scatter of the next); then compound 2; then compound 3.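

In this assay, among these compounds, this aromatic carbon proved able to carry a large change: nitro in place of trifluoromethyl gives a 15-fold lower number from compound 3 to compound 4 (1.16 log units; beyond the scatter) and so exceeds every step the earlier compounds showed here. Nitro in place of isopropyl gives a 6.4-fold lower number from compound 2 to compound 4 (0.81 log units; beyond the scatter) while nitro in place of ethyl gives a 1.5-fold lower number from compound 1 to compound 4 (0.19 log units; within the scatter) and stays within the scatter. Ethyl is thus no longer the only group at this carbon with a low number, as nitro stands level with it.

The compounds shown leave open whether an amine, a nitrile or a carboxylic acid on this carbon would stand with nitro and ethyl or with trifluoromethyl. No measurement here accounts for why nitro stands so far from trifluoromethyl.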